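The source may hold more compounds than are shown below. What is called first, only, known or untested is meant among the compounds shown, and "the series" means these compounds.

Measured compounds:
Compound 1, `CC(C)COc1cccc(-c2ccc(C(=O)N(Cc3cccc(OCCCCCC(=O)O)c3)C(C)C)cc2)c1`.
Compound 2, `CC(C)N(Cc1cccc(OCCCCCC(=O)O)c1)C(=O)c1ccc(-c2ccoc2)cc1`.
Compound 3, `CCOC(=O)CCCCCOc1cccc(CN(C(=O)c2ccc(-c3cccc(OCC(C)C)c3)cc2)C(C)C)c1`.

In an ADME assay on HEK293 cells (Homo sapiens) for cytotoxicity, read by CellTiter-Glo and resazurin assay, with a stated time of 72 h (a higher number here means that more compound is needed for the effect, a lower number that less compound is needed), compound 1 gives > 26000 nM, which is a limit of the assay rather than a number. In this assay compound 2 gives > 26000 nM, also a limit. In this assay compound 3 gives > 26000 nM, again a limit. The change from compound 1 to compound 2 is furan-3-yl in place of 3-(isobutoxy)phenyl on an aromatic carbon, and its step is a step that the two limits leave unreadable from compound 1 to compound 2. The cores of compound 1 and compound 3 differ by ethyl in place of hydrogen on an oxygen next to a carbonyl group, with a step that the two limits leave unreadable from compound 1 to compound 3. Compound 4, `CCOC(=O)CCCCCOc1cccc(CN(C(=O)c2ccc(-c3ccoc3)cc2)C(C)C)c1`, is not yet measured; it carries the same change as compound 2, (furan-3-yl in place of 3-(isobutoxy)phenyl on an aromatic carbon), made on the core of compound 3 at a place described in the same words. Because all three values sit at the limit of > 26000 nM in this assay, at which 3 of the 3 values shown sit, only a small step is expected, a number no higher from compound 3 to compound 4 (the limit leaves the size open). Compound 4 is expected to give 26000 nM, most likely again only a limit.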

Compound 4, half-maximal effective concentration: > 26000 nM
Compound 4: a limit, no number (the forecaster's own chance of this, stated with the estimate: 85%); the middle value sits exactly at the limit.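

In this assay the steps to compound 4 from compound 2 and from compound 3 cannot be read, because every value is a limit: the limit of > 26000 nM in this assay, at which 4 of the 4 values shown sit. The compounds shown leave open at what concentration, if any, compound 1, compound 2, compound 3 or compound 4 harms these cells.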